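The compounds below may be only part of what the source reports. "The series", "measured", "known", "first", "only" and "open" are said of these compounds alone.

Three compounds share one core and differ only in the aryl group on their amide-type nitrogen. Compound 1 `O=C(CSc1nc(Nc2ccccc2)c2ccccc2n1)Nc1cccc(F)c1` carries a 3-fluorophenyl group; in a functional assay on MDA-MB-231 cells (Homo sapiens) for inhibition, read by MTT assay, with a stated time of 72 h (a lower number here means a stronger inhibitor, a higher number a weaker inhibitor), compound 1 gives > 50000 nM, which is a limit of the assay rather than a number (the limit of > 50000 nM in this assay, at which 1 of the 3 values shown sits). Compound 2 `O=C(CSc1nc(Nc2ccccc2)c2ccccc2n1)Nc1ccc(F)cc1`, with a 4-fluorophenyl group, gives 34100 nM in this assay. Compound 3 `O=C(CSc1nc(Nc2ccccc2)c2ccccc2n1)Nc1ccc(Br)cc1`, with a 4-bromophenyl group, gives 11500 nM in this assay, the lowest of the two numbers obtained. The step of a 3.0-fold lower number from compound 2 to compound 3 (0.47 log units; beyond the scatter) and the step of an at least 4.3-fold lower number from compound 1 to compound 3 (0.63 log units; beyond the scatter) both end at compound 3.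

Compound 4 `O=C(CSc1nc(Nc2ccccc2)c2ccccc2n1)Nc1ccc([N+](=O)[O-])cc1` differs from compound 3 by nitro in place of bromo on an aromatic carbon. Among the measured compounds shown here, no measured step exchanges a halogen for a nitro group; the one change on that aromatic carbon, a 3.0-fold lower number from compound 2 to compound 3 (0.47 log units; beyond the scatter), traded a smaller halogen for a larger one. Whether a nitro group follows the bromine cannot be told from these three compounds, so the expected step of a 1.0-fold higher number from compound 3 to compound 4 (0.02 log units; within the scatter) is small, in either direction, and may not exceed the scatter. Compound 4 is therefore estimated at 12000 nM in this assay, with a range from 3500 nM to 50000 nM.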

Compound 4, half-maximal inhibitory concentration: 16800 nM
The estimate for compound 4 lay 1.4-fold (0.15 log units) below the measured number, and the stated range covers the measured number.
By their numbers in this assay, from the lowest: compounds 3 and 4 (each within the scatter of the next); then compound 2. At a limit, above all of these: compound 1.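

In this assay, the carbon that held a halogen also accepts a group that is not a halogen, with a 1.5-fold higher number from compound 3 to compound 4 (0.16 log units; within the scatter), so bromo and nitro cannot be told apart here. The nitro group also keeps a separation from fluoro, with a 2.0-fold lower number from compound 2 to compound 4 (0.31 log units; beyond the scatter), so among compounds 2, 3 and 4, fluoro alone stands apart, and the earlier bromo-for-fluoro step is no longer the only one of its kind. Compound 1 sits at a limit and not at a number, so an at least 2.9-fold lower number from compound 1 to compound 4 (0.47 log units; beyond the scatter) gives only a floor: the limit of > 50000 nM in this assay, at which 1 of the 4 values shown sits.

From the compounds shown here alone, whether an amine, a carboxylic acid or a methoxy group on this carbon would fall with bromo and nitro or with fluoro remains open. What bromo and nitro share that fluoro lacks cannot be read from these compounds.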